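Methylphenyl Sulfone Analogue: Expected Inhibition Unchanged

This account rests on a few compounds, and the source may have more. Where it says the series, first, only, none or still open, it means among the compounds named here.

Compound 2 `O=C(NCc1ccc(S(=O)(=O)c2ccc(F)c(F)c2)cc1)c1cc2cnccc2[nH]1` gives 10 nM in an assay for inhibition of Nicotinamide phosphoribosyltransferase (Homo sapiens), read by mass spectrometry, with stated times of 15 min and 30 min; on this read-out lower numbers stand for stronger inhibition and higher numbers for weaker inhibition. Compound 1 `O=C(NCc1ccc(S(=O)(=O)c2cccc(C(F)(F)F)c2)cc1)c1cc2cnccc2[nH]1` gives 8 nM in this assay, and the step of a 1.3-fold higher number from compound 1 to compound 2 (0.10 log units; within the scatter) leaves the two within the scatter of each other. Compound 3 `Cc1cccc(S(=O)(=O)c2ccc(CNC(=O)c3cc4cnccc4[nH]3)cc2)c1` differs from compound 2 by 3-methylphenyl in place of 3,4-difluorophenyl on a sulfonyl sulfur. Among the measured compounds shown here, the only measured step at this position, a 1.3-fold higher number from compound 1 to compound 2 (0.10 log units; within the scatter), stayed within the scatter, so the change to compound 3 is expected to shift this assay no further than that. Compound 3 is therefore estimated at 12 nM, between 5 nM and 30 nM. The expected step is a 1.2-fold higher number from compound 2 to compound 3 (0.08 log units; within the scatter), within the scatter.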

Compound 3, half-maximal inhibitory concentration: 8 nM
Beside the measured number, compound 3's estimate is 1.5-fold (0.18 log units) above it, within the range that was stated.
By their numbers in this assay, from the lowest: compounds 1, 3 and 2 (each within the scatter of the next).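

In this assay the change to 3-methylphenyl gives a 1.3-fold lower number from compound 2 to compound 3 (0.10 log units; within the scatter) and methyl in place of trifluoromethyl on an aromatic carbon gives no change at the digits printed from compound 1 to compound 3 (within the scatter) as well. The aryl group on the sulfonyl sulfur therefore need not carry fluorine to stay within the scatter, which compound 1 and compound 2, both fluorinated, could not show. No evidence here bears on why these groups read alike. Still open, on these data alone, is whether an aryl group carrying an amine or a carboxylic acid would read the same on this sulfur.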